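A few compounds are considered here, and "the series" means these few. Any claim that something is new, unique, unknown or untested is made for them only; others in the source may bear on it.

Of the compounds shown here, two of this small series have been tested in a functional assay (Homo sapiens) for inhibition of Nucleic Acid, tested at 100 uM; a lower number here means less inhibition, a higher number more inhibition at the concentration tested (going by the name of the read-out). Compound 1 `[N-]=[N+]=Nc1nccc2c1ncn2[C@H]1C[C@H](O)[C@@H](CO)O1` gives 4% in this assay. Compound 2 `Clc1[nH]ccc2ncnc1-2`, the bare core, gives 6% in this assay; compound 1 lies within the scatter of that number, so the two stand together at the bottom of the scale, with neither showing inhibition of note at the concentration used.

The next compound, compound 3 `OCCNc1[nH]ccc2ncnc1-2`, carries one change relative to compound 2: (2-hydroxyethyl)amino in place of chloro on an aromatic carbon. Going by the values given here, no measured pair shows what such a change does in this assay, so there is no step on which to lean. Given how little either measured compound inhibits, compound 3 is expected to move only by a number 2 percentage points higher from compound 2 to compound 3 (within the scatter), a step that would not rise beyond the scatter in either direction. On that basis compound 3 is estimated at 8% in this assay, in a range from -10% to 30%.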

Compound 3, a percentage reported as inhibition, at one concentration (the size of the read-out at that concentration, not a potency): 3%
The estimate for compound 3 lay 5 percentage points above the measured number, within the range that was stated.
By their numbers in this assay, from the lowest: compounds 3, 1 and 2 (each within the scatter of the next).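

Going by these compounds alone, exchanging chloro for (2-hydroxyethyl)amino on this aromatic carbon, next to the ring nitrogen, gives the first step at a single place that can be read in this assay: a number 3 percentage points lower from compound 2 to compound 3 (within the scatter). The four heavy atoms of the new chain, with its hydrogen-bond donors and acceptors, thus take the place of a single chlorine with no change in the read-out beyond the scatter, and inhibition stays without note at the concentration tested. Nothing at hand explains this outcome.

The compounds shown leave open whether any other group on this carbon, such as a simple amine, a longer chain ending in a carboxylic acid, or a benzylamine, would lift inhibition off the bottom of the scale. Within the data shown here, with only this one step, they also leave open whether the position matters at all in this assay.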